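The compounds below may be only part of what the source reports. "The series", "measured", "known", "first", "only" and "open" are said of these compounds alone.

Three compounds share one core: compound 1 `Cn1c(-c2ccc(NC(=O)CCl)cc2)nc(-c2ccccc2)c1-c1ccccc1`, compound 2 `Cn1c(-c2ccc(NC(=O)CSc3nc4cc(Cl)ccc4o3)cc2)nc(-c2ccccc2)c1-c1ccccc1` and compound 3 `Cn1nnnc1SCC(=O)Nc1ccc(-c2nc(-c3ccccc3)c(-c3ccccc3)n2C)cc1`. In a functional assay on HT-29 cells (Homo sapiens) for cytotoxicity, read by MTT assay, with a stated time of 24 h, tested at 80 ug/mL (on this read-out higher numbers stand for a stronger effect at the one concentration tested and lower numbers for a weaker effect), compound 1 gives 76.1%, compound 2 gives 79.6% and compound 3 gives 89%. Compound 3 holds the highest of the three numbers; its gap to compound 2 lies within the scatter, while the step of a number 12.9 percentage points higher from compound 1 to compound 3 (beyond the scatter) lies beyond it. Compound 4 `Cc1nnc(SCC(=O)Nc2ccc(-c3nc(-c4ccccc4)c(-c4ccccc4)n3C)cc2)s1` is not yet measured. It differs from compound 3 in one place: 5-methyl-1,3,4-thiadiazol-2-yl in place of 1-methyl-1H-tetrazol-5-yl on a sulfur.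

The step that bears most directly on this change is a number 9.4 percentage points higher from compound 2 to compound 3 (within the scatter), where one ring on the sulfur was swapped for another and the number moved within the scatter. The step of a number 3.5 percentage points higher from compound 1 to compound 2 (within the scatter) also stayed within the scatter, and only a number 12.9 percentage points higher from compound 1 to compound 3 (beyond the scatter) was modest. Swapping the ring on the sulfur once more is therefore expected to give a step of about a number 5 percentage points lower from compound 3 to compound 4 (within the scatter), not beyond the scatter. Compound 4 is estimated at 84%, in the range 74% to 94%.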

Compound 4, a percentage reported as activity, at one concentration (the size of the read-out at that concentration, not a potency): 90.5%
Compound 4: the middle estimate sits 6.5 percentage points below what was measured; measured number inside the range.
By their numbers in this assay, from the lowest: compounds 1, 2, 3 and 4 (each within the scatter of the next, the first and the last beyond it).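

In this assay, the change shows that the position on the sulfur tolerates a second small ring: 5-methyl-1,3,4-thiadiazol-2-yl, with 3 hetero atoms, in place of 1-methyl-1H-tetrazol-5-yl, with 4, gives a number 1.5 percentage points higher from compound 3 to compound 4 (within the scatter) and so no real change. Within the data shown here, the new compound also gives the first ring swap on this sulfur to pass the scatter, with a number 10.9 percentage points higher from compound 2 to compound 4 (beyond the scatter) against the 5-chloro-1,3-benzoxazol-2-yl group. Its step from the chloro starting point, a number 14.4 percentage points higher from compound 1 to compound 4 (beyond the scatter) and modest in size, shows that a second five-membered ring on the sulfur can also stand clear of the chloro compound.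

The compounds shown leave open whether the sulfur needs an aromatic ring at all, or whether a plain ethyl chain, a carboxylic acid or an amine there would hold the read-out. With one concentration tested, they show only the size of the effect at that concentration, and no measurement shown explains these steps.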